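Replacing an aryl group with oxan-4-yl: effect on plasma binding

The source may hold more compounds than are shown below. What is called first, only, known or untested is meant among the compounds shown, and "the series" means these compounds.

Measured compounds:
compound 1, `CS(=O)(=O)NC(=O)CCc1cn(-c2ccc(Br)cc2)nc1-c1ccc(Cl)cc1`, 0.00004
compound 2, `CS(=O)(=O)NC(=O)CCc1cn(-c2ccc(Br)cc2)nc1-c1cccnc1`, 0.00022

Both compounds share a core that differs only in one group on an aromatic carbon. In an ADME assay on a cell-free system (plasma, Homo sapiens) for protein binding, read by LC-MS, tested at 5 uM (a higher number here means a larger unbound share of the compound, a lower number a smaller unbound share), compound 1 gives 0.00004, the lowest of the two numbers; compound 2, the nearest, gives 0.00022. Within the data shown here, the single measured step is a 5.5-fold higher number from compound 1 to compound 2 (0.74 log units; beyond the scatter), a modest rise that lies beyond the scatter.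

Compound 3, `CS(=O)(=O)NC(=O)CCc1cn(-c2ccc(Br)cc2)nc1C1CCOCC1`, has not yet been measured. It differs from compound 1 in the same place as compound 2 does: oxan-4-yl in place of 4-chlorophenyl on an aromatic carbon. Among the measured compounds shown here, the only step that bears on this change is the one from compound 1 to compound 2, in which a ring with one hetero atom replaced the 4-chlorophenyl and the unbound fraction rose. Oxan-4-yl is likewise a six-membered ring with one hetero atom, here non-aromatic, and the expectation is therefore a rise of similar or somewhat larger size. Compound 3 is thus estimated at 0.0003, with a range from 0.00008 to 0.0012, meaning an expected step of a 7.5-fold higher number from compound 1 to compound 3 (0.88 log units; beyond the scatter).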

Compound 3, unbound fraction: 0.0007
Compound 3: middle estimate off by 2.3-fold (0.37 log units), on the low side; the range from low to high includes it.
By their numbers in this assay, from the lowest: compound 1; then compound 2; then compound 3.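

In this assay, among these compounds, the group on this aromatic carbon, next to the ring nitrogen, can shift the reading further than the earlier compounds showed: oxan-4-yl in place of 4-chlorophenyl gives a large step (an 18-fold higher number from compound 1 to compound 3 (1.24 log units; beyond the scatter)) where pyridin-3-yl had given only a modest one (a 5.5-fold higher number from compound 1 to compound 2 (0.74 log units; beyond the scatter)). The two replacements are also not equivalent, since oxan-4-yl in place of pyridin-3-yl gives a further rise (a 3.2-fold higher number from compound 2 to compound 3 (0.50 log units; beyond the scatter)), so a six-membered ring with one hetero atom does not fix the outcome here, and the non-aromatic ring gives the highest of the three numbers. Nothing available explains why these groups order themselves in this way.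

The compounds shown leave open whether the rise goes with the ring oxygen of oxan-4-yl or with the loss of the aromatic ring, a question that a cyclohexyl or a piperidin-4-yl group at this position would help to separate. They also leave open whether an open chain such as 2-methoxyethyl would behave like oxan-4-yl, and whether the step holds with a group other than 4-bromophenyl elsewhere on the shared core.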